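The source may hold more compounds than are shown below. What is called first, only, known or untested is meant among the compounds shown, and "the series" means these compounds.

Compounds measured in an ADME assay on MT2 cells (Homo sapiens) for cytotoxicity; on this read-out lower numbers stand for higher toxicity in this test and higher numbers for lower toxicity in this test:
- Compound 1 `Cc1nc2cc(C(=O)NCc3ccc(F)cc3)nn2c(-c2cc(F)c3c(c2C)CCCO3)c1[C@H](OC(C)(C)C)C(=O)O` gives > 40000 nM, which is a limit of this assay and not a number.
- Compound 2 `Cc1nc2cc(C(=O)NCc3ccc(F)cc3O)nn2c(-c2cc(F)c3c(c2C)CCCO3)c1[C@H](OC(C)(C)C)C(=O)O` gives > 40000 nM, again a limit rather than a number.

Compound 2 therefore stands at the assay's limit, and the step that the two limits leave unreadable from compound 1 to compound 2 cannot be sized, since (the limit of > 40000 nM in this assay, at which 2 of the 2 values shown sit). Compound 3 `Cc1nc2cc(C(=O)NCc3ccc(F)cc3N3CCCC3=O)nn2c(-c2cc(F)c3c(c2C)CCCO3)c1[C@H](OC(C)(C)C)C(=O)O` differs from compound 2 by 2-oxopyrrolidin-1-yl in place of hydroxy on an aromatic carbon. Among the measured compounds shown here, with both known values at the limit, no measured step bears on this change, so no step beyond the scatter is expected; compound 3 is estimated to give 60000 nM in this assay, a step that the limit leaves unreadable from compound 2 to compound 3 that is expected to be unreadable.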

Compound 3, half-maximal cytotoxic concentration: > 40000 nM
Compound 3 gave a limit, no number; the forecaster's own chance of this, stated with the estimate: 80%; the middle value does not contradict the limit.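

Compound 3 also sits at a limit rather than a number, so no step among compound 1, compound 2 and compound 3 can be read: the limit of > 40000 nM in this assay, at which 3 of the 3 values shown sit.

Whether hydroxy or 2-oxopyrrolidin-1-yl changes the cytotoxicity of these compounds at all stays open.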